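From phenyl to 2,4-dimethylphenyl on a shared core

The source may hold more compounds than are shown below. What is called first, only, known or untested is meant among the compounds shown, and "the series" means these compounds.

Within the data shown here, in a functional assay on B16-F10 cells (Mus musculus) for antiproliferative activity, read by MTT assay, with a stated time of 48 h (a higher number here means a weaker inhibitor, a lower number a stronger inhibitor), compound 2 `COc1ccc(/C=C/c2cc(OC)cc(OC)c2/C=C/C(=O)c2ccccc2)cc1` gives 3.7 ug/mL, and compound 1 `COc1ccc(/C=C/c2cc(OC)cc(OC)c2/C=C/C(=O)c2ccc(C(F)(F)F)cc2)cc1`, the only other compound measured, gives 4.3 ug/mL. Among the measured compounds shown here, compound 2 therefore stands within the scatter of its sole neighbour rather than clearly apart from it. Compound 3 `COc1ccc(/C=C/c2cc(OC)cc(OC)c2/C=C/C(=O)c2ccc(C)cc2C)cc1` keeps the shared core and differs from compound 2 as follows: 2,4-dimethylphenyl in place of phenyl on a carbonyl carbon. This places 2,4-dimethylphenyl in place of phenyl on a carbonyl carbon. For the measured compounds named here, one measured step bears on this change: hydrogen in place of trifluoromethyl on an aromatic carbon, which gave a 1.2-fold lower number from compound 1 to compound 2 (0.07 log units; within the scatter). Going by the values given here, no measured compound carries the 2,4-dimethylphenyl group, so this evidence is indirect, and no shift beyond the scatter is expected in this assay. The expected step is a 1.1-fold higher number from compound 2 to compound 3 (0.03 log units; within the scatter). For compound 3 the estimated value is 4 ug/mL, with an expected range of 2 ug/mL to 8 ug/mL.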

Compound 3, half-maximal inhibitory concentration: 4 ug/mL
The estimate for compound 3 equals the measured number at the digits printed, and the stated range covers the measured number.
By their numbers in this assay, from the lowest: compounds 2, 3 and 1 (each within the scatter of the next).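

In this assay, replacing phenyl with 2,4-dimethylphenyl on a carbonyl carbon gives a 1.1-fold higher number from compound 2 to compound 3 (0.03 log units; within the scatter) and so does not move the number beyond the scatter. Set against the trifluoromethyl compound, the same group gives a 1.1-fold lower number from compound 1 to compound 3 (0.03 log units; within the scatter) in the same assay, so all three aryl groups now shown at this place, including one carrying two methyl groups, lie within the scatter of one another. No measurement on these compounds offers a reason for this result.

Going by these compounds, whether any group at this place can shift the number beyond the scatter stays open, and an amine or a carboxylic acid on the ring, or a longer chain in place of the ring, would test that. Also open, on these data alone, is how a single methyl group on the ring would read.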